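The compounds below may be only part of what the source reports. "The series", "measured", "known", "first", "only" and "open" are said of these compounds alone.

Measured in a functional assay on LNCaP cells (Homo sapiens) for antiproliferative activity; on this read-out higher numbers stand for weaker inhibition and lower numbers for stronger inhibition:
- compound 1 `Cn1ncc(Cl)c1-c1cc(C(=O)N[C@@H]2CN[C@H](CC(O)CO)C[C@H]2c2ccc(Cl)c(Cl)c2)oc1Cl`: 70 nM
- compound 2 `Cn1ncc(Cl)c1-c1cc(C(=O)N[C@@H]2CN[C@H](CC(=O)O)C[C@H]2c2ccc(Cl)c(Cl)c2)oc1Cl`: 640 nM
- compound 3 `Cn1ncc(Cl)c1-c1cc(C(=O)N[C@@H]2CN[C@H](CC(=O)NC3CC3)C[C@H]2c2ccc(Cl)c(Cl)c2)oc1Cl`: 190 nM

Compound 3 holds the middle place of the three numbers. The a 2.7-fold higher number from compound 1 to compound 3 (0.43 log units; beyond the scatter) puts it above compound 1, and a 3.4-fold lower number from compound 2 to compound 3 (0.53 log units; beyond the scatter) puts it below compound 2.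

Next in this assay is compound 4 `Cn1ncc(Cl)c1-c1cc(C(=O)N[C@@H]2CN[C@H](CCO)C[C@H]2c2ccc(Cl)c(Cl)c2)oc1Cl`. Its change from compound 3 is hydroxymethyl in place of cyclopropylcarbamoyl on a saturated chain carbon bound to a saturated ring carbon. In other words, hydroxymethyl stands in place of cyclopropylcarbamoyl on a saturated chain carbon bound to a saturated ring carbon, which can also be read as (cyclopropylcarbamoyl)methyl to 2-hydroxyethyl.

Among the measured compounds shown here, no measured compound carries hydroxymethyl at this place, so the closest guide is compound 1, whose 1,2-dihydroxyethyl also holds hydroxy. The a 2.7-fold higher number from compound 1 to compound 3 (0.43 log units; beyond the scatter) is the most relevant measured step, since it has the same group, cyclopropylcarbamoyl, on the same carbon. Run in reverse, it points to a lower number for compound 4. The a 9.1-fold higher number from compound 1 to compound 2 (0.96 log units; beyond the scatter) concerns the carboxy compound and bears on this change only loosely.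

A modest step is therefore expected, not quite reaching back to compound 1 at 70 nM. The expected step is a 2.1-fold lower number from compound 3 to compound 4 (0.32 log units; beyond the scatter). For compound 4 the estimated value is 90 nM, with an expected range of 35 nM to 220 nM.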

Compound 4, half-maximal inhibitory concentration: 160 nM
Compound 4: the middle estimate sits 1.8-fold (0.25 log units) below what was measured, within the range that was stated.
By their numbers in this assay, from the lowest: compound 1; then compounds 4 and 3 (each within the scatter of the next); then compound 2.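

In this assay, hydroxymethyl in place of cyclopropylcarbamoyl gives a 1.2-fold lower number from compound 3 to compound 4 (0.07 log units; within the scatter), so on a saturated chain carbon bound to a saturated ring carbon, the ring-bearing amide and the much smaller 2-hydroxyethyl end read alike. A single hydroxy on this chain does not match the 1,2-dihydroxyethyl of compound 1, as a 2.3-fold higher number from compound 1 to compound 4 (0.36 log units; beyond the scatter) shows for the hydroxymethyl lost in that comparison, while a 4.0-fold lower number from compound 2 to compound 4 (0.60 log units; beyond the scatter) leaves the carboxy compound with the highest number of the four. The compounds shown come with no measurement that accounts for any of these steps.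

On these data alone, it remains open whether a primary amine or a methyl ether at the end of the 2-hydroxyethyl chain, or a longer chain ending in hydroxy, would stay with compound 3 and compound 4 or move toward compound 1. Also open, as far as these compounds go, is whether the close agreement of the amide and the 2-hydroxyethyl end extends to other amides, such as a dimethylamide, or holds on any read-out other than this assay.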